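This account rests on a few compounds, and the source may have more. Where it says the series, first, only, none or still open, it means among the compounds named here.

Compound 1, with the structure `CS/C(=N\C(=O)c1cc2ccccc2s1)NC(=O)c1cc2ccccc2s1`, is the reference point of this small set. In a functional assay on MCF7 cells (Homo sapiens) for cytotoxicity, read by MTT assay, with a stated time of 72 h (on this read-out lower numbers stand for stronger inhibition of growth and higher numbers for weaker inhibition of growth), compound 1 gives 9510 nM, the lowest of the three numbers recorded.

Two further measured compounds share a smaller core. Compound 3, `CS/C(=N\C(=O)c1cccs1)NC(=O)c1cccs1`, gives 44500 nM in this assay. Compound 2, `O=C(/N=C(/NC(=O)c1cccs1)[Se]Cc1ccccc1)c1cccs1`, gives 72500 nM in the same assay. The two differ in one place: a group of 8 heavy atoms (7 carbon, 1 selenium; one six-membered aromatic ring of carbon only) in place of a group of 2 heavy atoms (1 carbon, 1 sulfur; no ring), on a carbon with a double bond to nitrogen. The step this change made is a 1.6-fold higher number from compound 3 to compound 2 (0.21 log units; within the scatter), so the two values are not distinguishable within the usual reproducibility of the measurement.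

Compound 1 and compound 3 differ in their cores, and that difference is not broken down here; only the two values themselves show that compound 3 sits at a higher number than compound 1.

The unmeasured compound 4, `O=C(/N=C(/NC(=O)c1cc2ccccc2s1)[Se]Cc1ccccc1)c1cc2ccccc2s1`, stands to compound 1 as compound 2 stands to compound 3. The change is a group of 8 heavy atoms (7 carbon, 1 selenium; one six-membered aromatic ring of carbon only) in place of a group of 2 heavy atoms (1 carbon, 1 sulfur; no ring), on a carbon with a double bond to nitrogen, at a place described in the same words as for the earlier pair, so it is the same change applied to the core of compound 1.

For the measured compounds named here, because the one measured example of this change gave a 1.6-fold higher number from compound 3 to compound 2 (0.21 log units; within the scatter), the expectation for compound 4 is a step of similar size, a 1.6-fold higher number from compound 1 to compound 4 (0.20 log units; within the scatter). Compound 4 is therefore estimated to give 15000 nM in this assay, with a plausible range from 5000 nM to 45000 nM; a single precedent leaves that range wide.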

Compound 4, concentration for 50% growth inhibition: 37900 nM
Beside the measured number, compound 4's estimate is 2.5-fold (0.40 log units) below it; low and high end bracket the measured number.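

In this assay, placing the group that carries selenium and a six-membered aromatic ring on the core of compound 1, where methylsulfanyl stood, gives a 4.0-fold higher number from compound 1 to compound 4 (0.60 log units; beyond the scatter). Only this step lies clear of the scatter on its own, yet it cannot be told apart from the step on the smaller core, so the two cores are consistent with one shared size of effect for this change: the same change on two cores in this assay, a 1.6-fold higher number (0.21 log units; within the scatter) from compound 3 to compound 2 and a 4.0-fold higher number (0.60 log units; beyond the scatter) from compound 1 to compound 4, 2.4-fold (0.39 log units) apart, within the scatter of two such steps

From the compounds shown here alone, this does not make the change a rule for the series, since it rests on two pairs in a single assay and says nothing about how it would behave on any further core, and since selenium and the aromatic ring enter together, the share of each in the step stays unknown.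

The compounds shown leave open how a methylselanyl group or a benzylsulfanyl group would compare on the same carbon, and either would help to separate the selenium from the ring. They also leave open what an amine or a longer alkyl chain would do at that place, and how the four compounds would rank in any other read-out.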